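A few compounds are considered here, and "the series" means these few. Any claim that something is new, unique, unknown or untested is made for them only; others in the source may bear on it.

Compound 1 `CCc1ccc(NC2=CC(=O)c3c(nc4n3[C@H]3OC[C@@H](O)[C@H]3OC4)C2=O)cc1`: 1110 nM
Compound 2 `CCOc1ccc(NC2=CC(=O)c3c(nc4n3[C@H]3OC[C@@H](O)[C@H]3OC4)C2=O)cc1`: 2090 nM

In a functional assay on MGC-803 cells (Homo sapiens) for inhibition, read by sulforhodamine B assay (on this read-out higher numbers stand for weaker inhibition and lower numbers for stronger inhibition), compound 2 gives 2090 nM, which lies within the scatter of compound 1. Compound 3 `O=C1C(NC2CCCCC2)=CC(=O)c2c1nc1n2[C@H]2OC[C@@H](O)[C@H]2OC1` has cyclohexyl in place of 4-ethoxyphenyl on an amine nitrogen. For the measured compounds named here, the only measured step, a 1.9-fold higher number from compound 1 to compound 2 (0.27 log units; within the scatter), exchanges ethyl for ethoxy on an aromatic carbon, so no measured step replaces the aromatic ring itself. A modest step in this assay is therefore expected, leaning only weakly towards a higher number. The expected step is a 1.4-fold higher number from compound 2 to compound 3 (0.16 log units; within the scatter). For compound 3 the estimated value is 3000 nM, with an expected range from 800 nM to 11000 nM.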

Compound 3, half-maximal inhibitory concentration: > 8000 nM
Compound 3 gave a limit, no number; the forecaster's own chance of this, stated with the estimate: 5%; middle value at least 2.6-fold (0.42 log units) from the limit.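

In this assay compound 3 gives only a limit, > 8000 nM, not a number. For the compounds shown here, exchanging the aromatic ring on the amine nitrogen for a non-aromatic one is the first change here to go beyond the scatter, with an at least 3.8-fold higher number from compound 2 to compound 3 (0.58 log units; beyond the scatter) and an at least 7.2-fold higher number from compound 1 to compound 3 (0.85 log units; beyond the scatter). Changing the group on that aromatic ring, as between compound 1 and compound 2, stayed within the scatter, so among these compounds the read-out responds to the ring itself rather than to that group.

On these data alone, the full size of both steps remains open. So does how an unsubstituted phenyl, a pyridine or an open hexyl chain on that amine nitrogen would compare.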